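This account rests on a few compounds, and the source may have more. Where it says the series, first, only, none or still open, it means among the compounds named here.

Measured compounds in a functional assay on DU-145 cells (Homo sapiens) for cytotoxicity, in the presence of a further agent that is not named here; on this read-out lower numbers stand for stronger inhibition and higher numbers for weaker inhibition:
compound 1 `Clc1ccc(-c2cc(-c3cccnc3)nc(-c3ccsc3)c2)o1` gives 21600 nM
compound 2 `Clc1ccc(-c2cc(-c3cccnc3)nc(-c3cccs3)c2)o1` gives 13000 nM
compound 3 `Clc1ccc(-c2cc(-c3ccc(Cl)o3)cc(-c3cccs3)n2)cc1` gives 19200 nM

Compound 1 has the highest of the three numbers, but its distance to the other two is small: the step of a 1.7-fold lower number from compound 1 to compound 2 (0.22 log units; within the scatter) lies within the scatter, and compound 3 sits even closer to compound 1. The step of a 1.5-fold higher number from compound 2 to compound 3 (0.17 log units; within the scatter) is likewise within the scatter. Nothing among these three compounds therefore separates cleanly from the rest.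

Compound 4 `Clc1ccc(-c2cc(-c3ccsc3)nc(-c3ccccn3)c2)o1` is the next compound to be measured. It differs from compound 1 in one place: pyridin-2-yl in place of pyridin-3-yl on an aromatic carbon.

Among the measured compounds shown here, none of the measured steps concerns the pyridyl ring itself. The closest comparison is the swap of one thiophene isomer for another in the step from compound 1 to compound 2, which stayed within the scatter, and the replacement of the pyridyl ring by a chlorophenyl ring between compound 2 and compound 3, which also stayed within the scatter. On that basis no step beyond the scatter is expected for compound 4 in this assay, with a 1.0-fold lower number from compound 1 to compound 4 (0.01 log units; within the scatter) as the expected shift. Compound 4 is therefore estimated at 21000 nM, within a range from 8000 nM to 55000 nM.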

Compound 4, half-maximal inhibitory concentration: 10900 nM
Compound 4: middle estimate off by 1.9-fold (0.28 log units), on the high side; the measured number falls inside the stated range.
By their numbers in this assay, from the lowest: compounds 4, 2, 3 and 1 (each within the scatter of the next).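

In this assay, pyridin-2-yl in place of pyridin-3-yl on the aromatic carbon next to the ring nitrogen gives a 2.0-fold lower number from compound 1 to compound 4 (0.30 log units; within the scatter). Among the compounds shown here, this is the first reading of a change in how the pyridyl ring is attached at this position: the two compounds have the same atoms, joined differently, and the swap does not separate compound 4 from compound 1 beyond the scatter. Nothing measured here accounts for the size of this step.

All four compounds carry only aromatic rings on the shared core, so the compounds shown leave open whether a non-aromatic group at this position, such as a morpholine, a primary amine or a carboxylic acid, would give a step beyond the scatter. They also leave open whether the same swap of pyridyl isomers would give a step of similar size on the core of compound 2, which carries thiophen-2-yl in place of thiophen-3-yl.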